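Methyl to Cyano on the Indole Ring of a Carbamate

The source may report more compounds than this note shows. Statements on the series, on what has been measured and on what is new or still open speak of the compounds shown alone.

The measured compounds:
compound 1, `COc1ccc2c(ccn2CCC2CCN(C(=O)Oc3ccccc3)CC2)c1`, 360 nM
compound 2, `Cc1ccc2c(ccn2CCC2CCN(C(=O)Oc3ccccc3)CC2)c1`, 700 nM

Both compounds were tested in an assay on microsomes from brain for inhibition of Fatty-acid amide hydrolase 1 (Rattus norvegicus), read by HPLC, with a stated time of 60 min; a higher number here means a weaker inhibitor, a lower number a stronger inhibitor. Within the data shown here, compound 2 gives the highest of the two numbers; its nearest neighbour is compound 1, and the one step between them, a 1.9-fold higher number from compound 1 to compound 2 (0.29 log units; within the scatter), lies within the scatter. Compound 3, `N#Cc1ccc2c(ccn2CCC2CCN(C(=O)Oc3ccccc3)CC2)c1`, has not yet been measured. It differs from compound 2 in one place: cyano in place of methyl on an aromatic carbon. Among the measured compounds shown here, the only step at hand, from compound 1 to compound 2, concerns a different exchange at the same kind of site and was small; it does not directly show what a cyano group does there. Without a closer precedent, the expected step of a 1.2-fold lower number from compound 2 to compound 3 (0.07 log units; within the scatter) from compound 2 to compound 3 is none beyond the scatter. Compound 3 is therefore estimated at 600 nM, with a range from 200 nM to 2000 nM.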

Compound 3, half-maximal inhibitory concentration: 970 nM
Compound 3: the middle estimate sits 1.6-fold (0.21 log units) below what was measured; the range from low to high includes it.
By their numbers in this assay, from the lowest: compounds 1, 2 and 3 (each within the scatter of the next, the first and the last beyond it).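

In this assay, cyano in place of methyl on this aromatic carbon gives a 1.4-fold higher number from compound 2 to compound 3 (0.14 log units; within the scatter), so this exchange, which adds a triple bond and a hydrogen-bond acceptor, leaves no difference that can be read at this site. Among these compounds, the same compound supplies the only step at this position that lies beyond the scatter, a 2.7-fold higher number from compound 1 to compound 3 (0.43 log units; beyond the scatter), a modest step for cyano in place of methoxy, while methyl in place of methoxy had stayed within the scatter. Nothing at hand explains why methoxy and cyano differ here.

From the compounds shown here alone, it remains open whether an amine or a carboxylic acid on the same aromatic carbon would move the number beyond the scatter from compound 2. Also open, going by these compounds, is whether ethoxy, with its longer chain, would match compound 1 or fall closer to compound 3.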